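Hydroxy to Methyl on Two Related Cores

The source may hold more compounds than are shown below. What is called first, only, known or untested is meant among the compounds shown, and "the series" means these compounds.

Three compounds have been measured in a functional assay on HeLa cells (Homo sapiens) for inhibition, read by MTT assay, with a stated time of 72 h; on this read-out lower numbers stand for stronger inhibition and higher numbers for weaker inhibition:

compound 1 `O=c1cc(Cn2cc(-n3ccc4cc(I)ccc43)nn2)c2ccc(O)cc2o1`, 14200 nM
compound 2 `Cc1ccc2c(Cn3cc(-n4ccc5cc(I)ccc54)nn3)cc(=O)oc2c1`, 34400 nM
compound 3 `Cn1c(-c2cn(Cc3cc(=O)oc4cc(O)ccc34)nn2)nc2ccccc21`, 49200 nM

Compound 2 differs from compound 1 by methyl in place of hydroxy on an aromatic carbon; that change gave a 2.4-fold higher number from compound 1 to compound 2 (0.38 log units; beyond the scatter). Compound 3 carries a different core, and the difference between the two cores is not broken down here. Its value in this assay is the highest of the three, though next to compound 2 it lies within the scatter, while the gap to compound 1 lies beyond it.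

Compound 4 `Cc1ccc2c(Cn3cc(-c4nc5ccccc5n4C)nn3)cc(=O)oc2c1` has not yet been measured in this assay. It differs from compound 3 by methyl in place of hydroxy on an aromatic carbon, the same change that turned compound 1 into compound 2, at the same place. Because a 2.4-fold higher number from compound 1 to compound 2 (0.38 log units; beyond the scatter) was modest but beyond the scatter, a step of similar size is expected here, giving a 2.2-fold higher number from compound 3 to compound 4 (0.35 log units; beyond the scatter) as the estimate. On that basis compound 4 is estimated at 110000 nM, with a likely range from 45000 nM to 270000 nM in this assay.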

Compound 4, half-maximal inhibitory concentration: 17500 nM
Compound 4: the middle estimate sits 6.3-fold (0.80 log units) above what was measured; the measured number lies below the stated range.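

In this assay, methyl in place of hydroxy on an aromatic carbon gave a 2.8-fold lower number from compound 3 to compound 4 (0.45 log units; beyond the scatter), so the change did not carry over from one core to the other with the same direction. Set side by side, the two steps point opposite ways, and the gap between them lies beyond the scatter: the same change on two cores in this assay, a 2.4-fold higher number (0.38 log units; beyond the scatter) from compound 1 to compound 2 and a 2.8-fold lower number (0.45 log units; beyond the scatter) from compound 3 to compound 4, 6.8-fold (0.83 log units) apart, beyond the scatter of two such steps. This shows that in these four compounds the outcome of the change differs with the core that carries it, but with one pair on each core it does not show which feature of the cores accounts for the difference, nor what a further core would do.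

The compounds shown carry only hydroxy or methyl at this place, so it remains open how a methoxy group, an amine or a carboxylic acid there would fare on either core. From the compounds shown here alone, whether the same opposite directions would return with such groups also stays open.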